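The compounds below may be only part of what the source reports. "The series", "measured", "known", "first", "only" and "open" are said of these compounds alone.

Working notes on the series. The shared core of compound 1 `NCc1cn(CC(=O)Nc2sc3c(c2C(N)=O)CCCC3)nc1C(F)(F)F` carries an aminomethyl group on its triazole arm; in an assay on isolated protein with metabotropic glutamate receptor 1 (Homo sapiens) as the target (on this read-out lower numbers stand for an effect already at smaller amounts and higher numbers for an effect only at larger amounts of compound), compound 1 gives 794 nM, the lowest of the three numbers obtained so far. Compound 2 `CCNCc1cn(CCC(=O)Nc2sc3c(c2C(N)=O)CCCC3)nc1C(F)(F)F` gives 2510 nM in this assay, and compound 3 `CCN(CC)Cc1cn(CCC(=O)Nc2sc3c(c2C(N)=O)CCCC3)nc1C(F)(F)F` gives 2000 nM; both differ from compound 1 in more than one place, so the gaps to compound 1 are recorded only as what the values show. Within the data shown here, the single one-point step in the set concerns alkylation of the amine nitrogen: a 1.3-fold lower number from compound 2 to compound 3 (0.10 log units; within the scatter).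

Compound 4 `CC(C)NCc1cn(CC(=O)Nc2sc3c(c2C(N)=O)CCCC3)nc1C(F)(F)F` is not yet measured. It differs from compound 1 by isopropyl in place of hydrogen on an amine nitrogen. Among the measured compounds shown here, one measured step bears on this change, the ethyl addition on the same kind of nitrogen, which gave a 1.3-fold lower number from compound 2 to compound 3 (0.10 log units; within the scatter) and thus nothing beyond the scatter. For the measured compounds named here, no measured step covers a branched group at this nitrogen, and no measured step covers alkylation in the acetamide-linked sub-series to which compound 1 belongs, so the expectation rests on that one ethyl step alone. On that basis the step is expected to be a 1.1-fold lower number from compound 1 to compound 4 (0.05 log units; within the scatter), that is, within the scatter. Compound 4 is therefore estimated at 700 nM in this assay, with a range from 300 nM to 1600 nM.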

Compound 4, half-maximal effective concentration: 3160 nM
For compound 4 the middle estimate is 4.5-fold (0.65 log units) below the measured one; measured number outside the range, above it.
By their numbers in this assay, from the lowest: compound 1; then compounds 3, 2 and 4 (each within the scatter of the next).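

In this assay, among these compounds, isopropyl in place of hydrogen on an amine nitrogen gives a 4.0-fold higher number from compound 1 to compound 4 (0.60 log units; beyond the scatter) and is the first change at this kind of nitrogen to pass beyond the scatter, whereas the ethyl step gave a 1.3-fold lower number from compound 2 to compound 3 (0.10 log units; within the scatter) and showed nothing that could be read as an effect. The amine nitrogen is therefore not a position where any added alkyl group leaves the read-out unchanged, and within the pair of compound 1 and compound 4 the unsubstituted amino form holds the lower number. Compound 1 also remains the lowest of the four, with its steps to the others all beyond the scatter, and nothing available here bears on the reason for the rise at this nitrogen.

The compounds shown leave open whether the higher number follows from any alkyl group on this nitrogen or from the isopropyl group in particular, a question that a methyl, an ethyl or a cyclopropyl on the amine of the core of compound 1 would address. Among the compounds shown here, they also hold no pair differing only in the chain that carries the amide, so the part played by that chain in the two alkylation steps stays unresolved.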